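Bromo for fluoro on the 1,3-benzothiazol-2-yl analogue

The compounds below may be only part of what the source reports. "The series", "measured", "known", "first", "only" and "open" are said of these compounds alone.

Working notes on four compounds with one shared core. Compound 1 `Fc1ccc(-c2nnc(SCCCN3CCN(c4nc5ccccc5o4)CC3)o2)cc1` in a functional assay on HepG2 cells (Homo sapiens) for inhibition, read by MTT assay, with a stated time of 72 h (on this read-out higher numbers stand for weaker inhibition and lower numbers for stronger inhibition), gives 83800 nM. Compound 2 `Brc1ccc(-c2nnc(SCCCN3CCN(c4nc5ccccc5o4)CC3)o2)cc1` differs by bromo in place of fluoro on an aromatic carbon and in this assay compound 2 gives 67500 nM, a step of a 1.2-fold lower number from compound 1 to compound 2 (0.09 log units; within the scatter). Compound 3 `Fc1ccc(-c2nnc(SCCCN3CCN(c4nc5ccccc5s4)CC3)o2)cc1` differs from compound 1 by 1,3-benzothiazol-2-yl in place of 1,3-benzoxazol-2-yl on an amine nitrogen in a ring; in this assay compound 3 gives 234000 nM, a step of a 2.8-fold higher number from compound 1 to compound 3 (0.45 log units; beyond the scatter), and stands as the highest number of the three measured. Compound 4 `Brc1ccc(-c2nnc(SCCCN3CCN(c4nc5ccccc5s4)CC3)o2)cc1` is not yet measured; it differs from compound 3 by bromo in place of fluoro on an aromatic carbon, the same change as from compound 1 to compound 2, at a place described in identical words. Beside the earlier step, the step to compound 4 is expected to be a 1.2-fold lower number from compound 3 to compound 4 (0.08 log units; within the scatter), because the step of a 1.2-fold lower number from compound 1 to compound 2 (0.09 log units; within the scatter) stayed within the scatter. Compound 4 is therefore estimated at 195000 nM, with a range from 80000 nM to 450000 nM.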

Compound 4, half-maximal inhibitory concentration: 103000 nM
Beside the measured number, compound 4's estimate is 1.9-fold (0.28 log units) above it; low and high end bracket the measured number.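

In this assay, bromo in place of fluoro on the benzothiazole-bearing core gives a 2.3-fold lower number from compound 3 to compound 4 (0.36 log units; beyond the scatter) and does not differ from the same change on the core of compound 1: the same change on two cores in this assay, a 1.2-fold lower number (0.09 log units; within the scatter) from compound 1 to compound 2 and a 2.3-fold lower number (0.36 log units; beyond the scatter) from compound 3 to compound 4, 1.8-fold (0.26 log units) apart, within the scatter of two such steps.
The reverse reading, with the bromo held fixed, gives a 1.5-fold higher number from compound 2 to compound 4 (0.18 log units; within the scatter) and likewise does not differ from its counterpart with fluoro: the same change on two cores in this assay, a 2.8-fold higher number (0.45 log units; beyond the scatter) from compound 1 to compound 3 and a 1.5-fold higher number (0.18 log units; within the scatter) from compound 2 to compound 4, 1.8-fold (0.26 log units) apart, within the scatter of two such steps.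
The two changes therefore carry between these cores within the scatter, but one pair of steps for each change does not establish that they carry across the series or fix the size of either step.

As far as these compounds go, it remains open whether chloro, methoxy or a carboxylic acid in place of bromo would follow the same course. From the compounds shown here alone, a longer chain in place of the shared chain also remains open.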